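The source may hold more compounds than are shown below. What is called first, only, known or untested is meant among the compounds shown, and "the series" means these compounds.

Compound 3 `Cc1cc(C(=O)O)nn1Cc1cc(Br)ccc1OCc1ccccc1Cl` shows the highest number of the three measured compounds in a functional assay on CHO-K1 cells for antagonist activity at prostaglandin E2 receptor EP1 subtype (Homo sapiens), read by FLIPR (on this read-out lower numbers stand for stronger inhibition and higher numbers for weaker inhibition), where compound 3 gives 28.8 nM. Its nearest neighbour is compound 1 `Cc1cc(C(=O)O)nn1Cc1cc(Br)ccc1OCc1ccccc1`, for which this assay records 15.1 nM, so that a 1.9-fold higher number from compound 1 to compound 3 (0.28 log units; within the scatter) stays within the scatter. Compound 2 `Cc1cc(C(=O)O)nn1Cc1cc(Br)ccc1OCc1ccc(Cl)cc1Cl`, with 0.49 nM in this assay, lies furthest away: a 59-fold higher number from compound 2 to compound 3 (1.77 log units; beyond the scatter), and likewise a 31-fold lower number from compound 1 to compound 2 (1.49 log units; beyond the scatter). Compound 4 `COc1ccccc1COc1ccc(Br)cc1Cn1nc(C(=O)O)cc1C` differs from compound 3 by methoxy in place of chloro on an aromatic carbon. Bearing directly on this change is a 1.9-fold higher number from compound 1 to compound 3 (0.28 log units; within the scatter), which installs that same chloro and stays within the scatter; the large steps of a 59-fold higher number from compound 2 to compound 3 (1.77 log units; beyond the scatter) and a 31-fold lower number from compound 1 to compound 2 (1.49 log units; beyond the scatter) concern the other chloro. No step beyond the scatter is therefore expected in this assay; for compound 4 the expected step is a 1.2-fold lower number from compound 3 to compound 4 (0.06 log units; within the scatter). Compound 4 is estimated at 25 nM, with a range of 8 nM to 80 nM.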

Compound 4, inhibition constant: 69.2 nM
Compound 4: the middle estimate sits 2.8-fold (0.44 log units) below what was measured, and the stated range covers the measured number.
By their numbers in this assay, from the lowest: compound 2; then compounds 1 and 3 (each within the scatter of the next); then compound 4.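

On this aromatic carbon the substituent does matter in this assay, since a 2.4-fold higher number from compound 3 to compound 4 (0.38 log units; beyond the scatter) lies beyond the scatter, and methoxy also separates from hydrogen with a 4.6-fold higher number from compound 1 to compound 4 (0.66 log units; beyond the scatter) even though chloro did not. Compound 1 and compound 3 alone therefore gave a misleading picture of a position indifferent to substitution. With 2-methoxyphenyl in place of 2,4-dichlorophenyl, a 140-fold higher number from compound 2 to compound 4 (2.15 log units; beyond the scatter) is the widest step in the set. Going by these compounds, whether methyl, ethoxy or hydroxy on this carbon would follow chloro or methoxy stays open. Nothing measured here accounts for these steps.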